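The compounds below may be only part of what the source reports. "The series", "measured", "known", "first", "only" and "open" are said of these compounds alone.

Measured so far:
- compound 1, `Cc1cc(Nc2nc(NCc3ccc(Cl)cc3)nc3ccccc23)n[nH]1`: 380 nM
- compound 2, `Cc1cc(Nc2nc(NCc3ccc(Br)cc3)nc3ccccc23)n[nH]1`: 180 nM
- compound 3, `Fc1ccc(CNc2nc(Nc3cc(C4CC4)[nH]n3)c3cc(Cl)ccc3n2)c(F)c1`: 72 nM

Notes on the series. In an assay for inhibition of high affinity nerve growth factor receptor (Homo sapiens), read by HTRF, with a stated time of 30 min, in the presence of a further agent that is not named here (a higher number here means a weaker inhibitor, a lower number a stronger inhibitor), compound 1 gives 380 nM. Compound 2 carries bromo in place of chloro on an aromatic carbon, (bromo in place of chloro on an aromatic carbon), and in this assay compound 2 gives 180 nM; the step is a 2.1-fold lower number from compound 1 to compound 2 (0.32 log units; beyond the scatter). Compound 3 sits on a different core; the difference between the core of compound 3 and the core of compound 1 is not broken down here. In this assay compound 3 gives 72 nM, the lowest number of the three.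

Compound 4, `Fc1ccc(CNc2nc(Nc3cc(C4CC4)[nH]n3)c3cc(Br)ccc3n2)c(F)c1`, is not yet measured. It differs from compound 3 by bromo in place of chloro on an aromatic carbon, the same kind of change as from compound 1 to compound 2, though the place is not the same: in compound 1 the carbon is para to a large group, whereas in compound 3 it is part of a fused or bridged system of two rings, meta to a fused ring and para to a fused ring. Among the compounds with values here, the one measured instance of this change, a 2.1-fold lower number from compound 1 to compound 2 (0.32 log units; beyond the scatter), is modest, and it is seen in two pairs only, so it is taken as a rough guide rather than a rule. The expected step for compound 4 is a 1.6-fold lower number from compound 3 to compound 4 (0.20 log units; within the scatter), resting on compound 1 to compound 2 giving a 2.1-fold lower number from compound 1 to compound 2 (0.32 log units; beyond the scatter). Compound 4 is therefore estimated at 45 nM in this assay, with a likely range of 20 nM to 110 nM.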

Compound 4, half-maximal inhibitory concentration: 120 nM
For compound 4 the middle estimate is 2.7-fold (0.43 log units) below the measured one; the whole stated range lies below it.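

In this assay, bromo in place of chloro on the aromatic carbon gives a 1.7-fold higher number from compound 3 to compound 4 (0.22 log units; within the scatter), so this pair shows no separation between the two halogens at this place. Set beside the earlier pair, the same change does not carry over with a fixed size from one core to the other: the same change on two cores in this assay, a 2.1-fold lower number (0.32 log units; beyond the scatter) from compound 1 to compound 2 and a 1.7-fold higher number (0.22 log units; within the scatter) from compound 3 to compound 4, 3.5-fold (0.55 log units) apart, beyond the scatter of two such steps. This does not show what sets the two steps apart, since the pairs differ in the core and also in the place of the change, which in the newer pair is a carbon that is part of a fused or bridged system of two rings, and two pairs support no general rule for the series.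

The compounds shown leave open whether the gap follows the core or the place, which would take the same change at the same place on both cores, with each halogen measured on each. They also leave open how far the number moves on this carbon of the fused system with groups other than the two halogens, such as a nitrile, a methoxy group or an amine.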